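Aryl swap on the ring nitrogen of the pyridone amide series

The source may hold more compounds than are shown below. What is called first, only, known or untested is meant among the compounds shown, and "the series" means these compounds.

Working notes. In a functional assay on HeLa cells (Homo sapiens) for antiproliferative activity, read by MTT assay, with a stated time of 72 h (on this read-out higher numbers stand for weaker inhibition and lower numbers for stronger inhibition), compound 1 `CNC(=O)c1cc(Oc2ccc(NC(=O)c3nn(-c4ccccc4Cl)c(=O)cc3C)cc2F)ccn1` gives 9870 nM, and compound 2 `CCCNC(=O)c1cc(Oc2ccc(NC(=O)c3nn(-c4ccc(Br)cc4F)c(=O)cc3C)cc2F)ccn1` gives 53500 nM, the higher of the two numbers recorded so far and the weaker inhibitor by that read-out. Compound 3 `CCCNC(=O)c1cc(Oc2ccc(NC(=O)c3nn(-c4cccc(F)c4)c(=O)cc3C)cc2F)ccn1` is still to be measured in this assay; it differs from compound 2 in one place, (3-fluorophenyl in place of 4-bromo-2-fluorophenyl on an aromatic nitrogen). For the measured compounds named here, no single-change step between measured compounds is available to anchor this swap, so only a modest step toward a lower number is expected, a 2.1-fold lower number from compound 2 to compound 3 (0.33 log units; beyond the scatter), close to the scatter. For compound 3 the estimate in this assay is 25000 nM, with a range from 8000 nM to 80000 nM.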

Compound 3, half-maximal inhibitory concentration: 6660 nM
For compound 3 the middle estimate is 3.8-fold (0.57 log units) above the measured one; measured number outside the range, below it.
By their numbers in this assay, from the lowest: compounds 3 and 1 (each within the scatter of the next); then compound 2.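

In this assay, 3-fluorophenyl in place of 4-bromo-2-fluorophenyl on the aromatic nitrogen gives an 8.0-fold lower number from compound 2 to compound 3 (0.90 log units; beyond the scatter), so this position alone moves the read-out beyond the scatter with the rest of the molecule unchanged. Compound 1 and compound 2 differ in more than one place and could not show this. No measurement at hand accounts for the step.

The swap removes bromine and relocates fluorine together, and the compounds shown do not separate these two changes. On these data alone, how an amine or a carboxylic acid on this aryl ring would read remains open.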